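Swapping an Octyl Chain for a Fluorophenoxy Group

The source may report more compounds than this note shows. Statements on the series, on what has been measured and on what is new or still open speak of the compounds shown alone.

Compound 1, `CC(Oc1ccc(Oc2ccc(F)cc2)cc1)C(=O)Cn1nnc(-c2ccc(Cl)cc2)n1`: in an ADME assay on S9 fraction from liver (Rattus norvegicus) for metabolic stability, read by LC-MS, using NADPH, with a stated time of 30 min (a lower number here means that less of the compound is left, a higher number that more of the compound is left), compound 1 sits at the assay's limit, < 5%.
Compound 2, `CCCCCCCCc1ccc(OC(C)C(=O)Cn2nnc(-c3ccc(C(=O)OC)cc3)n2)cc1`: in this assay compound 2 gives 62%.

Among the compounds with values here, compound 2 holds the only true number here; the other result is a limit, not a number. Compound 3, `COC(=O)c1ccc(-c2nnn(CC(=O)C(C)Oc3ccc(Oc4ccc(F)cc4)cc3)n2)cc1`, differs from compound 2 by 4-fluorophenoxy in place of octyl on an aromatic carbon, in words 4-fluorophenoxy in place of octyl on an aromatic carbon. Within the data shown here, no measured pair isolates this change. The same 4-fluorophenoxy group appears in compound 1, which sits at the limit of < 5% in this assay, at which 1 of the 2 values shown sits, so a drop beyond the scatter is expected from compound 2 to compound 3, a number 42 percentage points lower from compound 2 to compound 3 (beyond the scatter). Compound 3 is expected to give 20%, within 5% to 45%.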

Compound 3, percent of the compound remaining: < 5%
Compound 3 was reported as a limit (the forecaster's own chance of this, stated with the estimate: 25%); middle value at least 15 percentage points from the limit.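

Putting 4-fluorophenoxy in place of octyl at this position removes most of the stability seen in this assay, giving a number at least 57 percentage points lower from compound 2 to compound 3 (beyond the scatter). The result for compound 3 is a limit, not a number, and the methoxycarbonyl group it shares with compound 2 does not keep it off that limit: the limit of < 5% in this assay, at which 2 of the 3 values shown sit. The step between compound 1 and compound 3 cannot be read, with a limit on either side.

On these data alone, whether a shorter chain such as butyl would leave more compound intact stays open. So does the effect of a plain phenoxy group, without the fluorine.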